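Replacing the anilide of compound 1 with a dimethylamide

This account rests on a few compounds, and the source may have more. Where it says the series, first, only, none or still open, it means among the compounds named here.

This account follows a series sharing one core, an acrylamide-bearing aryl group joined to a chlorinated pyrimidine that carries an anilino benzamide. Compound 1 `C=CC(=O)Nc1ccc(-c2nc(Cl)cc(Nc3ccc(C(=O)Nc4ccc(F)cc4)cc3)n2)cc1` is the (4-fluorophenyl)amide of that series; in a functional assay on Ramos cells (Homo sapiens) for antiproliferative activity, read by MTT assay, with a stated time of 48 h (a higher number here means a weaker inhibitor, a lower number a stronger inhibitor), compound 1 gives "not determined" (no result reported), so no single number stands for it. Compound 2 `C=CC(=O)Nc1ccc(-c2nc(Cl)cc(Nc3ccc(C(=O)Nc4cc(C(F)(F)F)cc(C(F)(F)F)c4)cc3)n2)cc1` carries a 3,5-bis(trifluoromethyl)phenyl amide instead, and in this assay compound 2 gives 6180 nM, a weak result. For the measured compounds named here, no step between measured compounds is recorded, so nothing can be said about the size of any change so far.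

Compound 3 `C=CC(=O)Nc1ccc(-c2nc(Cl)cc(Nc3ccc(C(=O)N(C)C)cc3)n2)cc1` is the compound to be measured. Compared with compound 1 the difference is dimethylamino in place of (4-fluorophenyl)amino on a carbonyl carbon. Going by the values given here, since compound 1 has no number, the step into compound 3 cannot be placed against it; the only anchor is compound 2. Against that anchor one might expect compound 3 to land in the same weak region, with a step in either direction not beyond the scatter being most plausible. On that basis compound 3 is expected to give about 5000 nM in this assay, with a range from 1500 nM to 20000 nM.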

Compound 3, half-maximal inhibitory concentration: > 50000 nM
Compound 3 was reported as a limit; the forecaster's own chance of this, stated with the estimate: 20%; middle value at least 10-fold (1.00 log units) from the limit.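

For the compounds shown here, no step from compound 1 to compound 3 can be read, as no single number stands for compound 1. In this assay compound 3 gives > 50000 nM, which is a limit of the assay and not a number. The compounds shown leave open how much the change from (4-fluorophenyl)carbamoyl to dimethylcarbamoyl alters the activity.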